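Imidazole in place of pyrimidine on the aminomethyl arm

A few compounds are considered here, and "the series" means these few. Any claim that something is new, unique, unknown or untested is made for them only; others in the source may bear on it.

Going by the values given here, compound 2 `Cc1cc(NCc2ncccn2)n2nc(C)c(-c3ccccc3)c2n1` is the one compound with a number in a physicochemical assay for solubility, read by HPLC, using the shake flask method, measured as kinetic solubility, with a stated time of 2 h, at pH 7.4 (a lower number here means a less soluble compound, a higher number a more soluble compound), where compound 2 gives 37900 nM. Compound 1 `Cc1ccc(-c2cnn3c(NCc4ccccn4)cc(C)nc23)cc1` reaches only a limit in this assay, < 5000 nM, so the limit of < 5000 nM in this assay, at which 1 of the 2 values shown sits, frames how the other value is read. Compound 3 `Cc1cc(NCc2c[nH]cn2)n2nc(C)c(-c3ccccc3)c2n1` differs from compound 2 by 1H-imidazol-4-yl in place of pyrimidin-2-yl on a saturated chain carbon bound to a nitrogen on an aromatic ring. Among the compounds with values here, with no measured step of this kind to lean on, the change from compound 2 to compound 3 is expected to be modest, a 1.5-fold higher number from compound 2 to compound 3 (0.16 log units; within the scatter), toward somewhat higher solubility. Compound 3 is therefore estimated at 55000 nM, within 20000 nM to 130000 nM.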

Compound 3, solubility: 14600 nM
Estimate against measurement, compound 3: 3.8-fold (0.58 log units) above, outside the stated range (below it).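

Exchanging pyrimidin-2-yl for 1H-imidazol-4-yl gives a 2.6-fold lower number from compound 2 to compound 3 (0.41 log units; beyond the scatter) in this assay. This first measured step shows that the ring on a saturated chain carbon bound to a nitrogen on an aromatic ring can move the read-out beyond the usual scatter, and that here the five-membered ring gives the lower number. Nothing measured in this set accounts for the direction or size of this step. Still open, going by these compounds, is how the same place would read with a carboxylic acid, a morpholine or a longer chain.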